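This account rests on a few compounds, and the source may have more. Where it says the series, first, only, none or still open, it means among the compounds named here.

Measured so far:
- compound 1 `O=C(O)/C=C/C(=O)c1ccc(Cl)cc1Cl`: in a functional assay on LS174T cells (Homo sapiens) for inhibition, read by MTT assay, with a stated time of 72 h (a higher number here means a weaker inhibitor, a lower number a stronger inhibitor), compound 1 gives > 100000 nM, which is a limit of the assay and not a number.
- compound 2 `CCc1ccc(C(=O)/C=C/C(=O)O)cc1`: in this assay compound 2 gives 21000 nM.

Among the measured compounds shown here, compound 2 therefore holds the only actual number in this assay; the other entry is the limit (the limit of > 100000 nM in this assay, at which 1 of the 2 values shown sits), at which compound 1 sits. For the measured compounds named here, no step between two measured compounds is available, so the size of any structural change is not yet known.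

Compound 3 `O=C(O)/C=C/C(=O)c1ccc(Cl)cc1` is the next compound to be measured. It differs from compound 2 by chloro in place of ethyl on an aromatic carbon. Both groups are small and uncharged, and nothing in the measured pair shows how such a swap shifts the read-out. The expected step is a 1.4-fold higher number from compound 2 to compound 3 (0.15 log units; within the scatter). Compound 3 is estimated at 30000 nM, in a range from 10000 nM to 100000 nM.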

Compound 3, half-maximal inhibitory concentration: 28700 nM
Estimate against measurement, compound 3: 1.0-fold (0.02 log units) above; the measured number falls inside the stated range.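

In this assay, chloro and ethyl on this aromatic carbon cannot be told apart, with the step (a 1.4-fold higher number from compound 2 to compound 3 (0.14 log units; within the scatter)) printed as within the scatter, so at this place a chloro serves about as well as an ethyl. Hydrogen in place of the second chloro of compound 1 is a larger change, and this step (an at least 3.4-fold lower number from compound 1 to compound 3 (0.54 log units; beyond the scatter)) is the first in the series to lie beyond the scatter, which shows that the read-out does respond to the substitution pattern on the ring. The value of compound 1 is a limit of the assay and not a number, so the step has only a lower bound: the limit of > 100000 nM in this assay, at which 1 of the 3 values shown sits.

The compounds shown leave open how a methoxy group, an amine or a longer chain would read in place of the ethyl. They also leave open whether an amide in place of the carboxylic acid would change the read-out.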